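Swapping a Nitro Group for Fluorine on the Styryl Ring

The source may hold more compounds than are shown below. What is called first, only, known or untested is meant among the compounds shown, and "the series" means these compounds.

Compound 1 `COc1ccccc1/C=C/C(=O)c1ccc(OCC(=O)N[C@H]2CCOC2=O)cc1`, compound 2 `CC(C)c1ccc(/C=C/C(=O)c2ccc(OCC(=O)N[C@H]3CCOC3=O)cc2)cc1` and compound 3 `O=C(COc1ccc(C(=O)/C=C/c2cccc([N+](=O)[O-])c2)cc1)N[C@H]1CCOC1=O` share one core and differ only in the group on the aromatic ring at the end of the double-bonded chain. In a functional assay on MGC-803 cells (Homo sapiens) for antiproliferative activity, read by MTT assay, with a stated time of 72 h (a lower number here means a stronger inhibitor, a higher number a weaker inhibitor), compound 1 gives 39400 nM. In this assay compound 2 gives 16800 nM. For compound 3 this assay reports only a limit, > 64000 nM, so no number is known for it. Compound 3 thus stands at the edge of what was measured, the point that the limit of > 64000 nM in this assay, at which 1 of the 3 values shown sits, marks. Compound 4 `O=C(COc1ccc(C(=O)/C=C/c2cccc(F)c2)cc1)N[C@H]1CCOC1=O` differs from compound 3 by fluoro in place of nitro on an aromatic carbon, in words fluoro in place of nitro on an aromatic carbon. Among the compounds with values here, two measured steps concern this same ring: an at least 1.6-fold higher number from compound 1 to compound 3 (0.21 log units; that floor lies within the scatter), and an at least 3.8-fold higher number from compound 2 to compound 3 (0.58 log units; beyond the scatter). Both run toward the nitro compound and toward the limit, so the reverse change is expected to bring the number back among the measured values, a step of an at least 2.1-fold lower number from compound 3 to compound 4 (0.32 log units; beyond the scatter). Compound 4 is therefore estimated at 30000 nM, between 10000 nM and 100000 nM.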

Compound 4, half-maximal inhibitory concentration: > 64000 nM
Compound 4 ended at the assay's limit; the forecaster's own chance of this, stated with the estimate: 35%; at least 2.1-fold (0.32 log units) between middle value and limit.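

With fluoro in place of nitro, this ring carbon still gives no number in this assay, so the 3-fluorophenyl compound stops at the same limit as the 3-nitrophenyl compound: the limit of > 64000 nM in this assay, at which 2 of the 4 values shown sit. Both values are limits and not numbers, so the step between these two compounds cannot be read. Compared with the other rings, the result is an at least 3.8-fold higher number from compound 2 to compound 4 (0.58 log units; beyond the scatter) and an at least 1.6-fold higher number from compound 1 to compound 4 (0.21 log units; that floor lies within the scatter), so only the first of these is a clear separation.

Going from 4-isopropylphenyl to 3-fluorophenyl changes both the group and its place on the ring, and the compounds shown leave open which of the two matters. A 4-fluorophenyl or 3-isopropylphenyl ring would separate those two changes, and a 3-aminophenyl ring would test whether any group at this carbon gives a number under the limit.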